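The compounds below may be only part of what the source reports. "The series", "measured", "known", "first", "only" and "open" are said of these compounds alone.

Three compounds share the same core. Compound 1 `CC(=O)SCC(=O)c1ccc(NS(=O)(=O)c2ccc(OC3CCCN(C)C3)cc2)nc1` gives 3700 nM in a functional assay on HCT-116 cells (Homo sapiens) for cytotoxicity; a lower number here means that less compound is needed, a higher number that more compound is needed for the effect. Compound 2 `COc1ccc(S(=O)(=O)Nc2ccc(C(=O)CSC(C)=O)cn2)cc1` gives 540 nM in this assay, and compound 3 `CC(=O)SCC(=O)c1ccc(NS(=O)(=O)c2ccc3c(c2)COOC3)nc1` gives 1200 nM. Compound 2 thus stands lowest of the three numbers shown, with compound 3 the nearest and compound 1 the furthest from it.

Compound 4 `CC(=O)SCC(=O)c1ccc(NS(=O)(=O)c2ccc(OCCCCN(C)C)cc2)nc1` has not yet been measured. Relative to compound 2 it carries 3-(dimethylamino)propyl in place of hydrogen on a saturated chain carbon bound to an oxygen on an aromatic ring. Within the data shown here, the only step recorded here that bears on this change is the one on the same oxygen on the aromatic ring: a 6.9-fold lower number from compound 1 to compound 2 (0.84 log units; beyond the scatter). Read in the reverse direction, enlarging the methoxy of compound 2 into the 1-methylpiperidin-3-yl ether of compound 1 raised the number. Compound 4 also enlarges that methoxy, into a 4-(dimethylamino)butoxy, so a rise of a similar order is the natural expectation, though the tail differs from that of compound 1 and the size is uncertain.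

Compound 4 is therefore expected to give about 2200 nM in this assay, within a range from 800 nM to 6000 nM. That corresponds to an expected step of a 4.1-fold higher number from compound 2 to compound 4 (0.61 log units; beyond the scatter).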

Compound 4, half-maximal effective concentration: 280 nM
Compound 4: middle estimate off by 7.9-fold (0.90 log units), on the high side, and the stated range ends above it.
By their numbers in this assay, from the lowest: compounds 4 and 2 (each within the scatter of the next); then compound 3; then compound 1.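

In this assay, the step at this position is small: a 1.9-fold lower number from compound 2 to compound 4 (0.29 log units; within the scatter), so on the saturated chain carbon bound to the oxygen, adding 3-(dimethylamino)propyl to the methoxy of compound 2 leaves the number within the scatter. Enlarging the group on this oxygen therefore does not by itself raise the number: compound 1 has a higher number than compound 2, whereas compound 4 goes against any such trend. The nature of the enlarged group matters, as the comparison of the two nitrogen-bearing groups shows a 13-fold lower number from compound 1 to compound 4 (1.12 log units; beyond the scatter), with 4-(dimethylamino)butyl, which has no ring, in place of 1-methylpiperidin-3-yl.

On these data alone, it remains open how the number responds to a shorter or longer chain ahead of the dimethylamino group, or to a primary amine or a carboxylic acid at the end of the chain. Nothing available here accounts for the gap between the 4-(dimethylamino)butyl and 1-methylpiperidin-3-yl groups.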